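Taking the Chloro Away From Compound 2

The source may report more compounds than this note shows. Statements on the series, on what has been measured and on what is new or still open speak of the compounds shown alone.

Compound 1 `CCN(CC)C(=S)SCc1cc(=O)c2ccc(Cl)cc2o1` and compound 2 `O=c1cc(CSC(=S)N2CCOCC2)oc2cc(Cl)ccc12` share one core and differ only in the amine on the thiocarbonyl carbon. In a functional assay on MCF7 cells (Homo sapiens) for antiproliferative activity, read by MTT assay, with a stated time of 72 h (on this read-out lower numbers stand for stronger inhibition and higher numbers for weaker inhibition), compound 1 gives only a limit of the assay, > 25000 nM. In this assay compound 2 likewise gives only a limit, > 25000 nM. The step that the two limits leave unreadable from compound 1 to compound 2 is therefore unreadable, since both values sit at the limit of > 25000 nM in this assay, at which 2 of the 2 values shown sit. Compound 2 thus stands at the limit, with no number beneath it. Compound 3 `O=c1cc(CSC(=S)N2CCOCC2)oc2ccccc12` follows from compound 2 by hydrogen in place of chloro on an aromatic carbon. No measured step concerns this change, and the one step shown cannot be read, so there is no basis to expect a shift beyond the scatter in this assay. For compound 3 the expected value is near the limit, 25000 nM with a range from 8000 nM to 80000 nM. This corresponds to an expected step of a number no higher from compound 2 to compound 3 (the limit leaves the size open).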

Compound 3, half-maximal inhibitory concentration: 21000 nM
Compound 3: the middle estimate sits 1.2-fold (0.08 log units) above what was measured, within the range that was stated.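

With hydrogen in place of chloro on this aromatic carbon, the series gains its first measured number rather than a limit: in this assay the change is an at least 1.1-fold lower number from compound 2 to compound 3 (0.07 log units; that floor lies within the scatter). From the compounds shown here alone, that size is only a floor, so the full size of the change remains unknown, and it may lie within the scatter or beyond it. Compound 1 and compound 2 remain at a limit of the assay, and the step between them cannot be read: the limit of > 25000 nM in this assay, at which 2 of the 3 values shown sit.

The compounds shown leave open whether a different group on this carbon, such as fluoro, methoxy or an amine, would move the number further. They also leave open whether diethylamino on the thiocarbonyl carbon, paired with hydrogen instead of chloro, would give a number that differs from that of compound 3.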